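The source may hold more compounds than are shown below. What is called first, only, known or untested is meant among the compounds shown, and "the series" means these compounds.

Measured so far:
- compound 1, `CCN(CC)c1nc(C)nc2c(-c3cnc(OC)cc3C)c(C)nn12`: 14.5 nM
- compound 2, `CCC(CC)Nc1nc(C)nc2c(-c3c(C)cc(N(C)C)nc3C)c(C)nn12`: 25.6 nM
- compound 3, `CCCN(CCC)c1nc(C)nc2c(-c3ccc(OC)nc3C)c(C)nn12`: 5.7 nM

All three were run in an assay on cell membranes for displacement of a labelled ligand from corticotropin-releasing factor receptor 1 (Rattus norvegicus); a higher number here means a weaker inhibitor, a lower number a stronger inhibitor. Compound 3 holds the lowest number of the three; compound 1 stands higher and compound 2 higher still, both gaps beyond the scatter. Going by the values given here, compound 2 carries a secondary (pentan-3-yl)amino group together with a dimethylamino-substituted pyridyl ring, compound 1 a tertiary diethylamino group with a methoxy-substituted pyridyl ring, so no single-change pair exists among the measured set and no step between them is computed.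

Compound 4, `CCCCC(C)Nc1nc(C)nc2c(-c3ccc(OC)nc3C)c(C)nn12`, is not yet measured. Relative to compound 3 it differs only at the amino substituent: (1-methylpentyl)amino in place of dipropylamino on an aromatic carbon. The same atoms are joined differently, so a tertiary amine becomes a secondary one with a branched chain.

Compound 2 shows that a secondary branched amine on this core is compatible with a number in the same range as the others, though its other ring differs. The change to compound 4 is expected to cost somewhat, with the step of a 1.9-fold higher number from compound 3 to compound 4 (0.29 log units; within the scatter) estimated as a small weakening, near the edge of the scatter. For compound 4 the estimate in this assay is 11 nM, within 3.5 nM to 35 nM.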

Compound 4, half-maximal inhibitory concentration: 5.1 nM
Estimate against measurement, compound 4: 2.2-fold (0.33 log units) above; the range from low to high includes it.
By their numbers in this assay, from the lowest: compounds 4 and 3 (each within the scatter of the next); then compounds 1 and 2 (each within the scatter of the next).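

In this assay, placing (1-methylpentyl)amino in place of dipropylamino on the aromatic carbon between two ring nitrogen atoms gives a 1.1-fold lower number from compound 3 to compound 4 (0.05 log units; within the scatter) and so leaves the reading unchanged within the scatter. Going by these compounds alone, this pair is the first that differs in one place, and it shows directly what compound 2 could only hint at with its different pyridyl ring: with the rest of the structure held fixed, this position accepts a branched secondary amine as well as a tertiary one. The hydrogen-bond donor that enters with the secondary amine, and the rearrangement of the same atoms into a single branched chain, leave no readable mark on the number for this pair.

On these data alone, whether this tolerance extends to a cyclic amine such as morpholine, to a much shorter chain, or to a chain bearing a hydroxyl group remains open, as does whether it holds alongside the other pyridyl substituents of compound 1 and compound 2. Nothing available here offers any independent measurement that bears on this result.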